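Series notes: phenyl to carbamoylethyl at the saturated ring carbon

The source may hold more compounds than are shown below. What is called first, only, known or untested is meant among the compounds shown, and "the series" means these compounds.

The series is tested in a functional assay on ileum (Cavia porcellus) for inhibition of Polyunsaturated fatty acid 5-lipoxygenase (Homo sapiens); a higher number here means a weaker inhibitor, a lower number a stronger inhibitor. Compound 1 `Cc1c(C)c2c(c(C)c1O)SCO2` gives 290 nM. Compound 2 `Cc1c(C)c2c(c(C)c1O)SC(c1ccccc1)O2` gives 71 nM, the lowest of the two numbers shown so far; its nearest neighbour is compound 1, reached by the step of a 4.1-fold lower number from compound 1 to compound 2 (0.61 log units; beyond the scatter), which stands beyond the scatter and is the only step measured to date.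

Compound 3 `Cc1c(C)c2c(c(C)c1O)SC(CCC(N)=O)O2` has not yet been measured in this assay. It differs from compound 2 in one place: 2-carbamoylethyl in place of phenyl on a saturated ring carbon. Within the data shown here, the one measured step that bears on this position is a 4.1-fold lower number from compound 1 to compound 2 (0.61 log units; beyond the scatter), showing that what sits on this saturated ring carbon matters, with phenyl bringing a modest gain over hydrogen. No measurement exists for any other group at this carbon, so the effect of 2-carbamoylethyl cannot be read off directly; the expectation is that part of the gain seen on going to phenyl is not kept, placing compound 3 nearer compound 1 than compound 2. Compound 3 is therefore estimated to give 200 nM in this assay, with a range from 60 nM to 700 nM, an expected step of a 2.8-fold higher number from compound 2 to compound 3 (0.45 log units; beyond the scatter).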

Compound 3, half-maximal inhibitory concentration: 520 nM
Compound 3: the middle estimate sits 2.6-fold (0.41 log units) below what was measured, and the stated range covers the measured number.
By their numbers in this assay, from the lowest: compound 2; then compounds 1 and 3 (each within the scatter of the next).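

In this assay, the gain seen with phenyl at the saturated ring carbon does not extend to every group placed there: 2-carbamoylethyl in place of phenyl gives a 7.3-fold higher number from compound 2 to compound 3 (0.86 log units; beyond the scatter) and thus loses that gain. Against hydrogen, the same group gives a 1.8-fold higher number from compound 1 to compound 3 (0.25 log units; within the scatter) and so cannot be told apart from the unsubstituted compound, leaving phenyl as the only one of the three groups whose steps to both others lie beyond the scatter. The position therefore responds to the identity of the group and not merely to the presence of one, although no supporting data explain the difference between phenyl and 2-carbamoylethyl.

The step from phenyl to 2-carbamoylethyl removes the aromatic ring and introduces the primary amide in a single change, so the compounds shown do not separate the contribution of either feature. A plain butyl chain, a benzyl group, a 4-chlorophenyl group or a carboxylic acid at this carbon would help to show whether the ring, the chain or the amide governs the result, and whether anything can exceed phenyl here.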